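The compounds below may be only part of what the source reports. "The series", "measured", "known", "first", "only" and "open" are said of these compounds alone.

Measured compounds:
Compound 1 `COc1ccc(-c2ccc(C(O)(c3c[nH]cn3)C(C)C)cc2)cc1`: 54 nM
Compound 2 `CC(=O)Nc1cccc(-c2ccc([C@](O)(c3c[nH]cn3)C(C)C)cc2)c1`: 26 nM
Compound 3 `CNS(=O)(=O)c1cccc(-c2ccc(C(O)(c3c[nH]cn3)C(C)C)cc2)c1`: 160 nM

All three values come from an assay on isolated protein for inhibition of steroid 17-alpha-hydroxylase/17,20 lyase (Homo sapiens); a higher number here means a weaker inhibitor, a lower number a stronger inhibitor. Among these three numbers compound 1 holds the second highest place: compound 2 gives a lower number and compound 3 a higher one, and both gaps lie beyond the scatter. For the measured compounds named here, none of the measured compounds differ from one another in a single place, so no single-change step in this assay is available as a guide.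

Compound 4 `CC(C)C(O)(c1ccc(-c2ccccn2)cc1)c1c[nH]cn1` has not been measured yet. It differs from compound 1 in one place: pyridin-2-yl in place of 4-methoxyphenyl on an aromatic carbon. The smaller aromatic group keeps one hydrogen-bond acceptor, now inside the ring, while the remainder of the shared core is unchanged. Going by the values given here, with no comparable step to lean on, the expectation is a modest step from compound 1 to compound 4 toward a higher number, close to the edge of the scatter, namely a 1.7-fold higher number from compound 1 to compound 4 (0.22 log units; within the scatter). For compound 4 the estimated value in this assay is 90 nM, with a range from 30 nM to 270 nM.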

Compound 4, half-maximal inhibitory concentration: 150 nM
For compound 4 the middle estimate is 1.7-fold (0.22 log units) below the measured one; low and high end bracket the measured number.
By their numbers in this assay, from the lowest: compound 2; then compound 1; then compounds 4 and 3 (each within the scatter of the next).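

In this assay the series now has its first single-change step: pyridin-2-yl in place of 4-methoxyphenyl gives a 2.8-fold higher number from compound 1 to compound 4 (0.44 log units; beyond the scatter) and so marks this place, para to a large group, as responsive to the group it carries. Both groups are a six-membered aromatic ring with the same count of hydrogen-bond acceptors, so matching that count does not hold the number at the level of compound 1. The change also moves the acceptor into the ring and lowers the heavy-atom count, and this single step cannot separate those two differences.

A plain phenyl group at the same place would help to separate them. No supporting measurement bears on the origin of this step.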